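The source may hold more compounds than are shown below. What is called first, only, known or untested is meant among the compounds shown, and "the series" means these compounds.

In a functional assay on MCF7 cells (Homo sapiens) for inhibition, read by MTT assay, with a stated time of 48 h, tested at 10 uM (a lower number here means less inhibition of growth, a higher number more inhibition of growth at the concentration tested), three amines on a saturated chain carbon bound to an aromatic carbon have been compared on the shared core. Compound 1 `CCN(CC)Cc1c(O)c([C@H]2CCN(C)C[C@H]2O)c2oc(C)cc(=O)c2c1O` gives 24%, compound 2 `Cc1cc(=O)c2c(O)c(CN3CCCC3CO)c(O)c([C@H]3CCN(C)C[C@H]3O)c2o1` gives 22%, and compound 3 `Cc1cc(=O)c2c(O)c(CN(C)CC(=O)O)c(O)c([C@H]3CCN(C)C[C@H]3O)c2o1` gives 27%, so compound 3 stands within the scatter of both others.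

The next step leads to compound 4 `Cc1cc(=O)c2c(O)c(CN(C(C)C)C(C)C)c(O)c([C@H]3CCN(C)C[C@H]3O)c2o1`: diisopropylamino in place of (carboxymethyl)(methyl)amino on a saturated chain carbon bound to an aromatic carbon. Diisopropylamino replaces (carboxymethyl)(methyl)amino at that same place.

All three measured steps concern this place: a number 2 percentage points lower from compound 1 to compound 2 (within the scatter), a number 3 percentage points higher from compound 1 to compound 3 (within the scatter) and a number 5 percentage points higher from compound 2 to compound 3 (within the scatter). None exceeds the scatter, although the groups exchanged in them differ considerably. Diisopropylamino itself has not been measured. Compound 1, which carries diethylamino, provides the nearest comparison at 24%. No step beyond the scatter is therefore expected in this assay.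

The expected change is a number 2 percentage points lower from compound 3 to compound 4 (within the scatter), which would lie within the scatter.

Compound 4 is expected at 25%, with an estimated range of 13% to 38%.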

Compound 4, percent growth inhibition at one concentration: 33%
Estimate against measurement, compound 4: 8 percentage points below, and the stated range covers the measured number.
By their numbers in this assay, from the lowest: compounds 2, 1, 3 and 4 (each within the scatter of the next, the first and the last beyond it).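

At this place, on a saturated chain carbon bound to an aromatic carbon, the series now holds its first step beyond the scatter in this assay with diisopropylamino in place of 2-(hydroxymethyl)pyrrolidin-1-yl: a number 11 percentage points higher from compound 2 to compound 4 (beyond the scatter) on the shared core. Against the two other amines the exchange reads as a number 6 percentage points higher from compound 3 to compound 4 (within the scatter) and as a number 9 percentage points higher from compound 1 to compound 4 (within the scatter) so diisopropylamino separates from 2-(hydroxymethyl)pyrrolidin-1-yl alone and not from (carboxymethyl)(methyl)amino or diethylamino. Nothing available here bears on why this one pair separates.

Open, going by these compounds, is whether a longer chain on the amine, such as dibutylamino, would separate from diisopropylamino at this place. Equally open, on these data alone, is how the unsubstituted pyrrolidin-1-yl or a morpholine ring would compare with the 2-(hydroxymethyl)pyrrolidin-1-yl group on the same core.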